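This account rests on a few compounds, and the source may have more. Where it says the series, first, only, none or still open, it means among the compounds named here.

Measured compounds and their values:
- compound 1, `CC(=O)OC[C@H]1O[C@@H](CC(=O)/C=C/c2cccc(NC(=O)Nc3ccccc3)c2)[C@H](OC(C)=O)[C@@H](OC(C)=O)[C@@H]1OC(C)=O`: 180000 nM
- compound 2, `CC(=O)O[C@@H]1[C@@H](OC(C)=O)[C@H](OC(C)=O)CO[C@H]1CC(=O)/C=C/c1cccc(NS(=O)(=O)c2ccc(C)cc2)c1`: 268000 nM
- compound 3, `CC(=O)O[C@@H]1[C@@H](OC(C)=O)[C@H](OC(C)=O)CO[C@H]1CC(=O)/C=C/c1cccc(NC(=S)Nc2ccccc2)c1`: 58700 nM

These three were tested in an ADME assay on Vero cells (Chlorocebus sabaeus) for cytotoxicity, read by resazurin assay, with a stated time of 2 days; on this read-out higher numbers stand for lower toxicity in this test and lower numbers for higher toxicity in this test. Compound 3 stands lowest of the three numbers, that is, it is the most toxic in this test: compound 1 sits above it by a gap beyond the scatter, and compound 2 sits furthest above it. Among the compounds with values here, the one step between neighbours that differ in a single place runs a 4.6-fold lower number from compound 2 to compound 3 (0.66 log units; beyond the scatter), where a thiourea-type group replaced a sulfonyl-bearing group on the ring nitrogen.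

Compound 4, `CC(=O)O[C@@H]1[C@@H](OC(C)=O)[C@H](OC(C)=O)CO[C@H]1CC(=O)/C=C/c1cccc(NC(=O)Nc2ccccc2)c1`, has not yet been measured. It differs from compound 3 by a group of 9 heavy atoms (7 carbon, 1 nitrogen, 1 oxygen; one six-membered aromatic ring of carbon only) in place of a group of 9 heavy atoms (7 carbon, 1 nitrogen, 1 sulfur; one six-membered aromatic ring of carbon only), on a nitrogen on an aromatic ring. Within the data shown here, no measured step covers exactly this exchange of sulfur for oxygen on the urea-like group. What does bear on it is compound 1, which carries the same phenylcarbamoyl group on a core that differs only in the sugar part, and compound 1 gives 180000 nM in this assay, a higher number than compound 3. The expectation is therefore a step upward, toward lower toxicity, of size a 2.6-fold higher number from compound 3 to compound 4 (0.41 log units; beyond the scatter). Compound 4 is estimated at 150000 nM, with a range from 60000 nM to 350000 nM.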

Compound 4, half-maximal cytotoxic concentration: 102000 nM
Compound 4: middle estimate off by 1.5-fold (0.17 log units), on the high side; the range from low to high includes it.
By their numbers in this assay, from the lowest: compounds 3, 4, 1 and 2 (each within the scatter of the next, the first and the last beyond it).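

In this assay the exchange of sulfur for oxygen on the group at this ring nitrogen gives a 1.7-fold higher number from compound 3 to compound 4 (0.24 log units; within the scatter) and so cannot be told apart from the ordinary spread of repeated measurements, which means the thiourea-type group and the phenylcarbamoyl group do not separate here. The (4-methylphenyl)sulfonyl group does stand apart on this same core: putting phenylcarbamoyl in its place gives a 2.6-fold lower number from compound 2 to compound 4 (0.42 log units; beyond the scatter) in the same direction as a 4.6-fold lower number from compound 2 to compound 3 (0.66 log units; beyond the scatter) for the sulfur-bearing group, so two different groups now show a lower number than the sulfonyl compound. Within the data shown here, the sugar part, which the earlier compounds could not address on its own, also makes no readable difference in this pair, since hydrogen in place of acetoxymethyl on a saturated ring carbon gives a 1.8-fold lower number from compound 1 to compound 4 (0.25 log units; within the scatter) in this test.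

Nothing in the data shown explains why the sulfonyl compound differs from the other two. On these data alone, it also stays open whether a plain acetyl group on this nitrogen would fall with the sulfonyl compound or with the other two, and whether free hydroxyl groups in place of the sugar acetates would leave the numbers where they are.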